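Antiproliferative series: aryl swap carried to a second core

A few compounds are considered here, and "the series" means these few. Any claim that something is new, unique, unknown or untested is made for them only; others in the source may bear on it.

Measured to date in a functional assay on SW480 cells (Homo sapiens) for antiproliferative activity, read by sulforhodamine B assay, with a stated time of 48 h; a higher number here means a weaker inhibitor, a lower number a stronger inhibitor:
Compound 1, `COc1ccc(C=C(C(=O)/C=C/c2cccc(OC)c2OC)C(=O)/C=C/c2cccc(OC)c2OC)cc1OC`, gives 410 nM.
Compound 2, `COc1cccc(/C=C/C(=O)C(=Cc2ccc(O)c(F)c2)C(=O)/C=C/c2cccc(OC)c2OC)c1OC`, gives 330 nM.
Compound 3, `COc1ccc(OC)c(/C=C/C(=O)C(=Cc2ccc(OC)c(OC)c2)C(=O)/C=C/c2cc(OC)ccc2OC)c1`, gives 560 nM.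

Compound 1 and compound 3 are built from the same atoms joined differently; the difference between the two cores is not broken down here. Compound 3 stands at the highest of the three numbers, but its gaps to compound 1 and to compound 2 are both within the scatter, so no order among the three compounds can be read from these values.

Compound 2 differs from compound 1 in one place only: 3-fluoro-4-hydroxyphenyl in place of 3,4-dimethoxyphenyl on a double-bonded chain carbon bound to a double-bonded chain carbon. The step it made was a 1.2-fold lower number from compound 1 to compound 2 (0.09 log units; within the scatter), that is, no resolved change in potency.

Compound 4, `COc1ccc(OC)c(/C=C/C(=O)C(=Cc2ccc(O)c(F)c2)C(=O)/C=C/c2cc(OC)ccc2OC)c1`, has not yet been measured. It differs from compound 3 by 3-fluoro-4-hydroxyphenyl in place of 3,4-dimethoxyphenyl on a double-bonded chain carbon bound to a double-bonded chain carbon. This is the same change, at the same place, as the one between compound 1 and compound 2; it occurs twice among the compounds shown, once measured and once not.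

On that single precedent, the step from compound 3 to compound 4 in this assay is expected to be a 1.2-fold lower number from compound 3 to compound 4 (0.08 log units; within the scatter), because the same change gave a 1.2-fold lower number from compound 1 to compound 2 (0.09 log units; within the scatter). One precedent on a different core is thin, so the range is kept wide. Compound 4 is therefore estimated at 470 nM, expected to fall between 250 nM and 900 nM.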

Compound 4, half-maximal inhibitory concentration: 510 nM
Compound 4: the middle estimate sits 1.1-fold (0.04 log units) below what was measured, within the range that was stated.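

In this assay, the swap of 3,4-dimethoxyphenyl for 3-fluoro-4-hydroxyphenyl on the second core gave a 1.1-fold lower number from compound 3 to compound 4 (0.04 log units; within the scatter), so again there is no resolved change in potency. Set beside the earlier step, the same change on the two cores cannot be told apart, and the two results agree: the same change on two cores in this assay, a 1.2-fold lower number (0.09 log units; within the scatter) from compound 1 to compound 2 and a 1.1-fold lower number (0.04 log units; within the scatter) from compound 3 to compound 4, 1.1-fold (0.05 log units) apart, within the scatter of two such steps. This shows that, in these two pairs, the swap carries from one core to the other without a resolved shift in the number; it does not show that the change has any effect of its own, since neither step is resolved, and two pairs say nothing about a third core or about any other assay.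

The compounds shown offer only these two aryl groups at this place, so they leave open whether a 4-hydroxyphenyl without the fluorine, or a 3-fluorophenyl without the hydroxyl, would read the same as the 3-fluoro-4-hydroxyphenyl. They also leave open whether an aryl group bearing an amine or a carboxylic acid, on a double-bonded chain carbon bound to a double-bonded chain carbon, would move the number beyond the scatter on either core.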